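A few compounds are considered here, and "the series" means these few. Any claim that something is new, unique, unknown or untested is made for them only; others in the source may bear on it.

Series notes. Among the measured compounds shown here, the shared core carries two six-membered aromatic rings of carbon only, and the three measured compounds differ only in the single groups placed on them. Compound 1 `Cc1ccc(-c2csc(NC(=O)COc3ccccc3)n2)cc1` gives 54900 nM in a functional assay on MDA-MB-468 cells (Homo sapiens) for cytotoxicity, read by MTT assay, with a stated time of 48 h; a lower number here means a stronger inhibitor, a higher number a weaker inhibitor. Compound 2 `O=C(COc1ccccc1)Nc1nc(-c2ccc(Cl)cc2)cs1` gives 55300 nM in this assay, and compound 3 `Cc1ccc(OCC(=O)Nc2nc(-c3ccc(C)cc3)cs2)cc1` gives 37200 nM in this assay. The step of a 1.0-fold higher number from compound 1 to compound 2 (0.00 log units; within the scatter) corresponds to the change (chloro in place of methyl on an aromatic carbon); the step of a 1.5-fold lower number from compound 1 to compound 3 (0.17 log units; within the scatter) corresponds to the change (methyl in place of hydrogen on an aromatic carbon). All three values lie within the scatter of one another, so no order among compounds 1, 2 and 3 can be read from these numbers.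

Compound 4 `Cc1ccc(-c2csc(NC(=O)COc3ccc(Cl)cc3)n2)cc1` is not yet measured in this assay. It differs from compound 3 by chloro in place of methyl on an aromatic carbon. The cores of compound 3 and compound 1 differ by methyl in place of hydrogen on an aromatic carbon. The place of the change from compound 3 to compound 4 is described in the same words as that from compound 1 to compound 2, so it is taken as the same change; read one bond further out it covers 4-methylphenoxy to 4-chlorophenoxy as well as 4-methylphenyl to 4-chlorophenyl. Because a 1.0-fold higher number from compound 1 to compound 2 (0.00 log units; within the scatter) was flat, a step of about a 1.1-fold higher number from compound 3 to compound 4 (0.03 log units; within the scatter) is expected for compound 4, within the scatter. Compound 4 is therefore estimated at 40000 nM in this assay, expected between 20000 nM and 80000 nM.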

Compound 4, half-maximal inhibitory concentration: 44200 nM
For compound 4 the middle estimate is 1.1-fold (0.04 log units) below the measured one; measured number inside the range.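

In this assay, chloro in place of methyl on an aromatic carbon gives no readable step on either core, and the two steps agree: the same change on two cores in this assay, a 1.0-fold higher number (0.00 log units; within the scatter) from compound 1 to compound 2 and a 1.2-fold higher number (0.07 log units; within the scatter) from compound 3 to compound 4, 1.2-fold (0.07 log units) apart, within the scatter of two such steps The new step, a 1.2-fold higher number from compound 3 to compound 4 (0.07 log units; within the scatter), reads as 4-methylphenoxy to 4-chlorophenoxy, and the other new step, a 1.2-fold lower number from compound 1 to compound 4 (0.09 log units; within the scatter), is also within the scatter. This shows that the flat result held on both cores, but it rests on two pairs only, with 4-methylphenyl to 4-chlorophenyl in one and 4-methylphenoxy to 4-chlorophenoxy in the other, and agreement between two steps within the scatter does not show that a larger effect would carry from one core to another.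

The compounds shown leave open whether any replacement on these aromatic rings gives a step beyond the scatter, for example an amine or a carboxylic acid in place of chloro, or a longer chain in place of methyl. Since every step here lies within the scatter, they also leave open whether a step of readable size, once found on one core, would recur on the other.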